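Phenoxy to Methoxy: A Change Without a Measured Precedent

The source may report more compounds than this note shows. Statements on the series, on what has been measured and on what is new or still open speak of the compounds shown alone.

In an ADME assay on PC-3 cells (Homo sapiens) for cytotoxicity, read by WST assay, tested at 100 uM (a higher number here means more inhibition at the concentration tested (going by the name of the read-out), a lower number less inhibition), three compounds have been measured:
compound 1 `O=C(Nc1ccc(Cl)cc1)C1CCCN(C(=O)c2cccc(-c3nccs3)c2)C1`: 32%
compound 2 `O=C(Nc1cccc(Oc2ccccc2)c1)C1CCCN(C(=O)c2cc(C(F)(F)F)cc(C(F)(F)F)c2)C1`: 1%
compound 3 `CS(=O)(=O)c1cccc(C(=O)N2CCCC(C(=O)Nc3ccc(Cl)cc3)C2)c1`: 2%

Compound 2 stands lowest of the three in this assay; its nearest neighbour is compound 3, within the scatter, while compound 1 lies furthest from it, beyond the scatter. Compound 4 `COc1cccc(NC(=O)C2CCCN(C(=O)c3cc(C(F)(F)F)cc(C(F)(F)F)c3)C2)c1` differs from compound 2 by methyl in place of phenyl on an oxygen on an aromatic ring. Going by the values given here, the only measured step, a number 30 percentage points lower from compound 1 to compound 3 (beyond the scatter), concerns a different position and a different pair of groups, so no measured step bears on the phenoxy-to-methoxy change. With compound 2 already near the bottom of the observed range, compound 4 is therefore expected to stay within the scatter, and its estimated step is a number 2 percentage points higher from compound 2 to compound 4 (within the scatter). Compound 4 is expected to give 3%, in a range from 0% to 15%.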

Compound 4, a percentage reported as inhibition, at one concentration (the size of the read-out at that concentration, not a potency): 0%
Compound 4: middle estimate off by 3 percentage points, on the high side; low and high end bracket the measured number.
By their numbers in this assay, from the lowest: compounds 4, 2 and 3 (each within the scatter of the next); then compound 1.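

Going by these compounds alone, this is the first measured step at this position: in this assay, it is a number 1 percentage points lower from compound 2 to compound 4 (within the scatter). Methyl in place of phenyl on an oxygen on an aromatic ring removes a six-membered aromatic ring of carbon only, yet compound 2 and compound 4 cannot be told apart in this read-out. No measurement at hand accounts for this result. On these data alone, whether an amine or a carboxylic acid at this place would give a step beyond the scatter stays open. So does whether phenoxy to methoxy reads the same on another core.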